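This account rests on a few compounds, and the source may have more. Where it says the series, first, only, none or still open, it means among the compounds named here.

Three compounds have been measured in a physicochemical assay for solubility, read by spectrophotometry, with stated times of 1 h and 30 min; on this read-out lower numbers stand for lower solubility and higher numbers for higher solubility:

Compound 1 `COc1ccccc1/C=C/C=C/C(=O)c1ccc([N+](=O)[O-])cc1`: 13.9 ug/mL
Compound 2 `O=C(/C=C/C=C/c1ccccc1)c1ccccc1Cl`: 8.2 ug/mL
Compound 3 `CC(C)c1ccc(C(=O)/C=C/C=C/c2ccccc2)cc1`: 6.78 ug/mL

Compound 3, at 6.78 ug/mL, lies within the usual scatter of compound 2, at 8.2 ug/mL, so these two values cannot be told apart. Compound 1, at 13.9 ug/mL, stands higher than compound 3, and that gap lies just beyond the scatter.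

The account now moves from compound 3 to compound 4 `O=C(/C=C/C=C/c1ccccc1)c1ccc([N+](=O)[O-])cc1`, which has not yet been measured in this assay. The change is nitro in place of isopropyl on an aromatic carbon, para to a large group (nitro in place of isopropyl on an aromatic carbon).

Among the measured compounds shown here, no pair of measured compounds differs in one place only, so the size of this step cannot be read directly from the data. For the measured compounds named here, the only guide is compound 1, which also carries a nitro, para to a large group, and gives 13.9 ug/mL. It differs from compound 4 elsewhere as well, so it offers only a loose pointer.

On that basis, a small rise that stays within the scatter is expected, with an estimated 1.6-fold higher number from compound 3 to compound 4 (0.21 log units; within the scatter). For compound 4 the expected value is 11 ug/mL, with an estimated range of 5.5 ug/mL to 22 ug/mL.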

Compound 4, solubility: 13.2 ug/mL
For compound 4 the middle estimate is 1.2-fold (0.08 log units) below the measured one; the range from low to high includes it.
By their numbers in this assay, from the lowest: compounds 3, 2, 4 and 1 (each within the scatter of the next, the first and the last beyond it).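

In this assay nitro in place of isopropyl on an aromatic carbon, para to a large group, now has a direct reading in a 1.9-fold higher number from compound 3 to compound 4 (0.29 log units; within the scatter) and so, at this position, the two groups cannot be told apart on this read-out. Among the compounds shown here, the second pair adds a comparison that the earlier compounds lacked: hydrogen in place of methoxy on an aromatic carbon, with the nitro present on both sides, gives a 1.1-fold lower number from compound 1 to compound 4 (0.02 log units; within the scatter) and so the methoxy group of compound 1 cannot be told apart from hydrogen either. Nothing available bears on why these two steps have the size they do.

The compounds shown leave open whether an amine or a carboxylic acid on the same aromatic carbon would give a step beyond the scatter, where neither nitro nor isopropyl has done so here. They also leave open whether hydrogen in place of methoxy would read the same with isopropyl rather than nitro on the other aromatic ring of the shared core.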